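A Small Amine Swap Across Two Inactive Cores

This account rests on a few compounds, and the source may have more. Where it says the series, first, only, none or still open, it means among the compounds named here.

Within the data shown here, compound 1 `CN(C)Cc1ccc(NC(=O)NN=C(c2ccccn2)c2ccccn2)cc1` is the first of three measured compounds. In a functional assay on U-937 cells (Homo sapiens) for antiproliferative activity, read by CCK-8 assay, with a stated time of 24 h (on this read-out higher numbers stand for weaker inhibition and lower numbers for stronger inhibition), compound 1 gives > 40000 nM, which is a limit of the assay and not a number. Compound 2 `CCN(CC)Cc1ccc(NC(=O)NN=C(c2ccccn2)c2ccccn2)cc1` differs from compound 1 only by diethylamino in place of dimethylamino on a saturated chain carbon bound to an aromatic carbon. In this assay compound 2 gives > 40000 nM, again a limit. Both of these sit at the limit of > 40000 nM in this assay, at which 2 of the 3 values shown sit, so the change shows a step that the two limits leave unreadable from compound 1 to compound 2.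

Compound 3 `CN(C)Cc1ccc(NC(=O)NN=C(c2ccccc2)c2ccccc2)cc1` keeps the (dimethylamino)methyl group of compound 1 but carries a different core; the difference between the two cores is not broken down here. In this assay compound 3 gives > 25000 nM, once more a limit. Among the measured compounds shown here, compound 3 is the single compound that sits at the limit of > 25000 nM in this assay, at which 1 of the 3 values shown sits.

Compound 4 `CCN(CC)Cc1ccc(NC(=O)NN=C(c2ccccc2)c2ccccc2)cc1` has not been measured. It differs from compound 3 by diethylamino in place of dimethylamino on a saturated chain carbon bound to an aromatic carbon, the same change that separates compound 2 from compound 1. Because compound 3 shows only > 25000 nM in this assay, and because the earlier step reads a step that the two limits leave unreadable from compound 1 to compound 2, there is no measured effect of this change on which to build a numerical shift. The step from compound 3 to compound 4 is therefore estimated as a step that the limit leaves unreadable from compound 3 to compound 4. Compound 4 is expected to give about 50000 nM in this assay. The expected range for compound 4 runs from 20000 nM to 200000 nM, with a limit rather than a number the most likely outcome.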

Compound 4, half-maximal inhibitory concentration: > 25000 nM
Compound 4: only a limit was reported; the forecaster's own chance of this, stated with the estimate: 85%; the middle value does not contradict the limit.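

In this assay compound 4 gives > 25000 nM, which is a limit of the assay and not a number. Compound 3 and compound 4 therefore share one limit, and no step between them can be read: the limit of > 25000 nM in this assay, at which 2 of the 4 values shown sit.

The compounds shown leave open what diethylamino in place of dimethylamino does on either core, and whether any of the four has a measurable half-maximal inhibitory concentration in this assay.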